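Adding a furan ring where an alkyne stood

A few compounds are considered here, and "the series" means these few. Any claim that something is new, unique, unknown or untested is made for them only; others in the source may bear on it.

Compound 3 `C#Cc1cn([C@@H]2O[C@H](CO)[C@@H](O)[C@H]2O)c2nc(N)nc(OC)c12` carries an ethynyl group on its core. In a functional assay on CCRF-CEM cells (Homo sapiens), read by MTT assay, with a stated time of 72 h (on this read-out lower numbers stand for stronger inhibition and higher numbers for weaker inhibition), compound 3 gives > 100000 nM, which is a limit of the assay rather than a measured number. Compound 2 `COc1nc(N)nc2c1c(-c1cccs1)cn2[C@@H]1O[C@H](CO)[C@@H](O)[C@H]1O` shares the same amino-bearing core but carries thiophen-2-yl. In this assay compound 2 gives > 20000 nM, again a limit of the assay. Among the compounds with values here, the only measured step, a step that the two limits leave unreadable from compound 2 to compound 3, therefore cannot be read in size. Compound 1 `COc1ncnc2c1c(-c1ccoc1)cn2[C@@H]1O[C@H](CO)[C@@H](O)[C@H]1O` carries furan-3-yl but lacks the amino group; in this assay compound 1 gives 110 nM.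

Compound 4 `COc1nc(N)nc2c1c(-c1ccoc1)cn2[C@@H]1O[C@H](CO)[C@@H](O)[C@H]1O` differs from compound 3 as follows: furan-3-yl in place of ethynyl on an aromatic carbon. Compound 4 thus combines the furan-3-yl of compound 1 with the amino-bearing core of compounds 2 and 3. The two limits at the limit of > 100000 nM in this assay, at which 1 of the 3 values shown sits, and the limit of > 20000 nM in this assay, at which 1 of the 3 values shown sits, give no readable direction for the coming step. Given that both measured compounds on this core stop at a limit, compound 4 is expected to remain weak, with an estimated value of 15000 nM in the range 1500 nM to 100000 nM, implying an expected step of an at least 6.6-fold lower number from compound 3 to compound 4 (0.82 log units; beyond the scatter).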

Compound 4, half-maximal inhibitory concentration: > 20000 nM
Compound 4: only a limit was reported (the forecaster's own chance of this, stated with the estimate: 50%); at least 1.3-fold (0.12 log units) between middle value and limit.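

The new result shifts attention from the group on the five-membered ring to the amino group. With furan-3-yl held constant in this assay, amino in place of hydrogen gives an at least 180-fold higher number from compound 1 to compound 4 (2.25 log units; beyond the scatter), and this size is bounded only from one side, as the value of compound 4 is a limit of the assay. Compounds 2, 3 and 4 all stop at limits, so the steps among them cannot be read, and compound 4 shares its limit with compound 2: the limit of > 20000 nM in this assay, at which 2 of the 4 values shown sit.

As far as these compounds go, it remains open whether any group at this position can give a measurable number on the amino-bearing core, a phenyl ring or a longer chain for instance. From the compounds shown here alone, it is equally open whether a smaller replacement for the amino group, such as methyl or chlorine, would keep the number of compound 1.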